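This account rests on a few compounds, and the source may have more. Where it says the series, first, only, none or still open, it means among the compounds named here.

Compound 1 `Cc1ccc(S(=O)(=O)NC(=N)N2CCN(c3cc4c(cc3F)c(=O)c(C(=O)O)cn4C3CC3)CC2)cc1` gives 43 nM in a functional assay on HL-60 cells (Homo sapiens) for antiproliferative activity, read by MTT assay, with a stated time of 72 h; a higher number here means a weaker inhibitor, a lower number a stronger inhibitor.
Compound 2 `N=C(NS(=O)(=O)c1ccc(C(F)(F)F)cc1)N1CCN(c2cc3c(cc2F)c(=O)c(C(=O)O)cn3C2CC2)CC1` gives 43 nM in this assay.
Compound 3 `CCn1cc(C(=O)O)c(=O)c2cc(F)c(N3CCN(C(=N)NS(=O)(=O)c4ccccc4C(F)(F)F)CC3)cc21` gives 43 nM in this assay.

Compound 3 stands level with compounds 1 and 2 on these numbers. Compound 4 `N=C(NS(=O)(=O)c1ccccc1C(F)(F)F)N1CCN(c2cc3c(cc2F)c(=O)c(C(=O)O)cn3C2CC2)CC1` differs from compound 3 in a single place: cyclopropyl in place of ethyl on an aromatic nitrogen. Going by the values given here, the one measured single step, no change at the digits printed from compound 1 to compound 2 (within the scatter), concerns the sulfonyl ring and not this position, so it bears on the change only as a sign that this series has so far been flat. Compounds 1 and 2 already carry cyclopropyl on the aromatic nitrogen and sit at the same value as compound 3 with its ethyl, though they differ from it elsewhere as well. The step is therefore expected to stay within the scatter: no change at the digits printed from compound 3 to compound 4 (within the scatter). Compound 4 is expected to give 43 nM in this assay, between 20 nM and 90 nM.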

Compound 4, half-maximal inhibitory concentration: 43 nM
The estimate for compound 4 equals the measured number at the digits printed; measured number inside the range.
By their numbers in this assay, from the lowest: compounds 1, 2, 3 and 4 (each within the scatter of the next).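

In this assay, going by these compounds alone, the first direct reading at the aromatic nitrogen shows that cyclopropyl in place of ethyl leaves the value where it was (no change at the digits printed from compound 3 to compound 4 (within the scatter)). On the sulfonyl sulfur, 2-(trifluoromethyl)phenyl also matches 4-(trifluoromethyl)phenyl (no change at the digits printed from compound 2 to compound 4 (within the scatter)) and 4-methylphenyl (no change at the digits printed from compound 1 to compound 4 (within the scatter)). Nothing available explains why these values coincide. As far as these compounds go, it remains open whether a longer chain such as butyl or a phenyl ring on that nitrogen would hold the value. From the compounds shown here alone, an amine or a carboxylic acid on the sulfonyl phenyl ring is equally open.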